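The compounds below may be only part of what the source reports. "The series", "measured", "known", "first", "only" and "open" are said of these compounds alone.

Measured in a functional assay for antagonist activity at transient receptor potential cation channel subfamily V member 1 (Homo sapiens), read by FLIPR and calcium flux; a higher number here means a weaker inhibitor, a lower number a stronger inhibitor:
compound 1 `O=C1CSc2ccc(NC(=O)C3CCN(c4cc(F)c(F)c(F)c4)CC3)cc2N1`: 1960 nM
compound 2 `O=C1COc2ccc(NC(=O)C3CCN(c4ccccc4Br)CC3)cc2N1`: 160 nM
compound 3 `COC(=O)CC1Oc2ccc(NC(=O)C3CCN(c4cc(F)cc(F)c4)CC3)cc2NC1=O`: 890 nM

Compound 2 gives the lowest number of the three; the gap to compound 3 and the larger gap to compound 1 both lie beyond the scatter. Among the measured compounds shown here, no two measured compounds differ in a single place, so no step between them can be read directly. Compound 4 `Cc1ccccc1N1CCC(C(=O)Nc2ccc3c(c2)NC(=O)CO3)CC1` departs from compound 2 by one change: methyl in place of bromo on an aromatic carbon. The two groups are each of one heavy atom, and in the absence of a measured step of this kind, only a small shift in this assay is expected from compound 2 to compound 4, if anything slightly toward a weaker inhibitor, near the scatter, a 1.6-fold higher number from compound 2 to compound 4 (0.21 log units; within the scatter). Compound 4 is accordingly estimated at 260 nM with a range of 100 nM to 700 nM.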

Compound 4, half-maximal inhibitory concentration: 150 nM
Estimate against measurement, compound 4: 1.7-fold (0.24 log units) above; measured number inside the range.
By their numbers in this assay, from the lowest: compounds 4 and 2 (each within the scatter of the next); then compound 3; then compound 1.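

In this assay, among the compounds shown here, the only readable step is a 1.1-fold lower number from compound 2 to compound 4 (0.03 log units; within the scatter), so 2-bromophenyl to 2-methylphenyl stays within the scatter. On this aromatic carbon, ortho to a large group, bromo and methyl are therefore not told apart in this pair, which compound 1 and compound 3, differing from compound 2 in several places, could not show. No evidence on hand bears on this result.

On these data alone, whether an amine, a methoxy group or a carboxylic acid at this place would give a similar number remains open. As far as these compounds go, whether the same holds with a different core also remains open.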